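Adding two carbons to the saturated ring of compound 2

The source may hold more compounds than are shown below. What is called first, only, known or untested is meant among the compounds shown, and "the series" means these compounds.

Measured compounds:
- Compound 1, `CC(=O)N[C@@H]1CCC[C@H](C(=O)Nc2cc(-c3cnn4c3CCCC4)ccn2)C1`: 33 uL/min
- Compound 2, `CC(=O)N[C@@H]1CCC[C@H](C(=O)Nc2cc(-c3cnc4n3CCC4)c(Cl)cn2)C1`: 19 uL/min
- Compound 3, `CC(=O)N[C@@H]1CCC[C@H](C(=O)Nc2cc(-c3cnn4c3CC(C)(C)C4)c(C)cn2)C1`: 53 uL/min

All three were measured in an ADME assay on cells (Hepatocyte, Rattus norvegicus) for metabolic stability, using equilibrium dialysis; on this read-out lower numbers stand for slow clearance and higher numbers for fast clearance. Compound 2 has the lowest number of the three. Its nearest neighbour is compound 1, whose value in this assay is higher by an amount that stays within the usual scatter of this kind of measurement, so the two cannot be told apart with confidence. Compound 3 stands furthest away, with a number that lies beyond the scatter, so compound 3 clears faster than compound 2.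

Compound 4, `CC(=O)N[C@@H]1CCC[C@H](C(=O)Nc2cc(-c3cnc4n3CC(C)(C)C4)c(Cl)cn2)C1`, has not yet been measured. It differs from compound 2 in one place: a group of 10 heavy atoms (8 carbon, 2 nitrogen; one five-membered non-aromatic ring with 1 hetero atom, one five-membered aromatic ring with 2 hetero atoms) in place of a group of 8 heavy atoms (6 carbon, 2 nitrogen; one five-membered non-aromatic ring with 1 hetero atom, one five-membered aromatic ring with 2 hetero atoms), on an aromatic carbon. Among the measured compounds shown here, the only measured compound that carries the five-membered non-aromatic ring with two extra carbons is compound 3, but compound 3 also differs from compound 2 in the chloro group and in the aromatic ring, so no clean comparison exists. The higher number of compound 3 hints that the step from compound 2 to compound 4 in this assay may go upward, but only by a modest amount, likely within the scatter. Compound 4 is therefore expected to give 28 uL/min, between 14 uL/min and 55 uL/min, which corresponds to an expected step of a 1.5-fold higher number from compound 2 to compound 4 (0.17 log units; within the scatter).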

Compound 4, intrinsic clearance in a liver preparation (reported as CLH), per the amount of preparation that the assay uses: 28 uL/min
Compound 4: the middle estimate sits on the measured number at the digits printed; measured number inside the range.
By their numbers in this assay, from the lowest: compounds 2, 4, 1 and 3 (each within the scatter of the next, the first and the last beyond it).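

In this assay, among the compounds shown here, the step is a 1.5-fold higher number from compound 2 to compound 4 (0.17 log units; within the scatter), and it is the first comparison here in which only one place changes, so the two added carbons on the saturated five-membered ring can be judged without the chloro group or the aromatic ring changing alongside them. That step lies within the usual scatter, so compound 2 and compound 4 cannot be told apart, and at this position, ortho to a chloro group, the group of 10 heavy atoms gives a clearance reading that cannot be distinguished from that of the group of 8 heavy atoms. No measurement available here bears on the reason for this result.

The compounds shown leave open whether a single methyl group or a hydroxyl group on the saturated ring would also leave the clearance reading indistinguishable from that of compound 2. They also leave open whether the two added carbons would give the same result if a fluorine or a nitrile stood in place of the chloro group.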